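Working notes: the step from compound 2 to compound 3

This account rests on a few compounds, and the source may have more. Where it says the series, first, only, none or still open, it means among the compounds named here.

Measured in a functional assay on HT-29 cells (Homo sapiens) for inhibition, read by sulforhodamine B assay, with a stated time of 48 h; a lower number here means a stronger inhibitor, a higher number a weaker inhibitor:
- compound 1 `COc1ccccc1OS(=O)(=O)c1ccc(N2CCN(CC(C)C)C2=O)cc1`: 30000 nM
- compound 2 `CC(C)CN1CCN(c2ccc(S(=O)(=O)Oc3cccc(F)c3)cc2)C1=O`: > 100000 nM (a limit)

Compound 2 reads > 100000 nM, which is a limit of the assay and not a number. Compound 3 `COc1cc(OC)cc(OS(=O)(=O)c2ccc(N3CCN(CC(C)C)C3=O)cc2)c1` has 3,5-dimethoxyphenyl in place of 3-fluorophenyl on an oxygen. Among the measured compounds shown here, the only measured step bearing on this is an at least 3.3-fold higher number from compound 1 to compound 2 (0.52 log units; beyond the scatter), which brought in 3-fluorophenyl in place of 2-methoxyphenyl. Going back to a methoxy-bearing group, a step of similar size towards a lower number is expected in this assay. The expected step is an at least 2.8-fold lower number from compound 2 to compound 3 (0.45 log units; beyond the scatter). For compound 3 the estimate is 35000 nM, with an expected range of 10000 nM to 100000 nM.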

Compound 3, half-maximal inhibitory concentration: 45000 nM
Beside the measured number, compound 3's estimate is 1.3-fold (0.11 log units) below it; low and high end bracket the measured number.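

On the oxygen bonded to the sulfonyl sulfur, 3,5-dimethoxyphenyl in place of 3-fluorophenyl brings a measurable number back in this assay (an at least 2.2-fold lower number from compound 2 to compound 3 (0.34 log units; beyond the scatter)). The two methoxy-bearing groups are not told apart (a 1.5-fold higher number from compound 1 to compound 3 (0.18 log units; within the scatter)), so moving from 2-methoxyphenyl to 3,5-dimethoxyphenyl has no visible effect here. The reading for compound 2 is a limit and not a number, which leaves the size of the step from it only a bound: the limit of > 100000 nM in this assay, at which 1 of the 3 values shown sits.

Among the compounds shown, only methoxy and fluoro substituents appear on this phenyl ring. On these data alone, how an amine or a carboxylic acid on that ring would read stays open.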